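Removing the Drawn Stereocentre: Compound 2 to Compound 3

The source may hold more compounds than are shown below. What is called first, only, known or untested is meant among the compounds shown, and "the series" means these compounds.

Compound 1, `CCCC(C)n1c(CC)nc2c(-c3ccc(Cl)cc3Cl)nccc21`: 3 nM
Compound 2, `CCC[C@@H](C)n1c(CC)nc2c(-c3ccc(OC(F)(F)F)cc3Cl)nccc21`: 1.9 nM

Both numbers come from an assay for binding affinity to Corticotropin releasing factor receptor (Rattus norvegicus); on this read-out higher numbers stand for weaker inhibition and lower numbers for stronger inhibition. Compound 2 holds the lowest of the two numbers, and its nearest neighbour is compound 1, whose number is higher by a gap that sits within the scatter, so neither compound can be called the stronger binder.

Compound 3, `CCCC(C)n1c(CC)nc2c(-c3ccc(OC(F)(F)F)cc3Cl)nccc21`, is still to be measured in this assay. the two compounds have the same atoms and bonds; at least one stereo element is drawn with a configuration in one of them and without one in the other: 1 of 1 stereo elements differ; a stereocentre at a saturated chain carbon is drawn R in compound 2 and without a configuration in compound 3 A structure drawn without a configuration at that carbon usually stands for a mixture of the two mirror-image forms, of which compound 2 is one. Within the data shown here, no step between measured compounds bears on such a change. If compound 2 is the more active form, a mixture would be expected to give a somewhat higher number; if it is the less active form, a lower one. The step of a 1.7-fold higher number from compound 2 to compound 3 (0.23 log units; within the scatter) is expected to be small and to stay within the scatter. Compound 3 is therefore estimated at 3.2 nM, with a range from 1.3 nM to 9 nM.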

Compound 3, inhibition constant: 2.8 nM
Compound 3: the middle estimate sits 1.1-fold (0.06 log units) above what was measured; the range from low to high includes it.
By their numbers in this assay, from the lowest: compounds 2, 3 and 1 (each within the scatter of the next).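

Among these compounds, compound 3 gives the first comparison at the stereocentre on the saturated chain carbon, and in this assay the step is small: a 1.5-fold higher number from compound 2 to compound 3 (0.17 log units; within the scatter). At this level of scatter, the assay does not separate the form drawn R from the form drawn without a configuration, and the only difference it tests is this: the fact that one of compounds 2 and 3 is drawn with a defined configuration and the other without, at the place where they differ. Among the compounds shown here, compound 3 also allows the first comparison of the aromatic groups at a single place, with trifluoromethoxy in place of chloro, and this step is small as well: a 1.1-fold lower number from compound 1 to compound 3 (0.03 log units; within the scatter).

From the compounds shown here alone, how the mirror-image form drawn S reads on its own remains open, so the role of this stereocentre is not settled. Also open, going by these compounds, is how a longer chain or a cyclopropylmethyl group would read at this place.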